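Working notes: a smaller amide end in compound 4

The compounds below may be only part of what the source reports. "The series", "measured", "known", "first", "only" and "open" are said of these compounds alone.

Measured compounds:
Compound 1 `CC(C)(C)c1ccc(C(=O)N2CCC3(CC2)C(=O)N(CC(=O)N2CCCC(C(N)=O)C2)CN3c2ccccc2)cc1` gives 16900 nM.
Compound 2 `CC(C)(C)OC(=O)N1CCN(C(=O)CN2CN(c3ccccc3)C3(CCN(C(=O)c4ccc(C5CCCCC5)cc4)CC3)C2=O)CC1` gives 3500 nM.
Compound 3 `O=C(CN1CN(c2ccccc2)C2(CCN(C(=O)c3ccc(C4CCCCC4)cc3)CC2)C1=O)N1CCN(S(=O)(=O)c2ccccc2)CC1` gives 14200 nM.

All three values come from an assay on HEK293 cells for displacement of a labelled ligand from NPC1-like intracellular cholesterol transporter 1 (Homo sapiens); a lower number here means a stronger inhibitor, a higher number a weaker inhibitor. Compound 1 holds the highest number of the three; compound 3 lies within the scatter of it, whereas compound 2 sits beyond the scatter below it. For the measured compounds named here, the only step with a single change, a 4.1-fold higher number from compound 2 to compound 3 (0.61 log units; beyond the scatter), concerns a swap on an amine nitrogen in a ring at the far end of the shared acetamide arm, and shows that changes in that region move the number modestly.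

Compound 4 `CC(C)(C)c1ccc(C(=O)N2CCC3(CC2)C(=O)N(CC(=O)NCN)CN3c2ccccc2)cc1` is not yet measured. It differs from compound 1 by (aminomethyl)amino in place of 3-carbamoylpiperidin-1-yl on a carbonyl carbon. Going by the values given here, this is a change in the same acetamide arm, though a far deeper cut than the one in the step from compound 2 to compound 3. Among the compounds with values here, no measured compound carries so small a group there, so the direction is uncertain; the value for compound 4 is expected to stay near that of compound 1, with a 1.2-fold higher number from compound 1 to compound 4 (0.07 log units; within the scatter) as the estimated step. The estimate for compound 4 is 20000 nM, with a range from 6000 nM to 60000 nM.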

Compound 4, half-maximal inhibitory concentration: 26500 nM
Compound 4: middle estimate off by 1.3-fold (0.12 log units), on the low side; measured number inside the range.
By their numbers in this assay, from the lowest: compound 2; then compounds 3, 1 and 4 (each within the scatter of the next).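

In this assay, the (aminomethyl)amino group in place of 3-carbamoylpiperidin-1-yl on a carbonyl carbon gives a 1.6-fold higher number from compound 1 to compound 4 (0.20 log units; within the scatter), so this step stays within the scatter. The earlier single-change step altered only a group on an amine nitrogen in a ring and kept that ring, whereas this one removes the ring and its carbamoyl group, going from 9 heavy atoms to 3. For this pair, the six-membered ring at the end of the arm is therefore not needed to keep the number at this level. No measurement at hand bears on the reason for this result.

From the compounds shown here alone, whether a carboxylic acid or a longer chain, such as aminoethyl or aminopropyl, at this position would move the number beyond the scatter remains open. Also open is whether the same cut gives a similar result with cyclohexyl in place of tert-butyl on the benzoyl group, and no pair shown isolates that swap.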